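A Larger Amide-Bearing Ring Replaces the Hydroxycyclobutyl

This account rests on a few compounds, and the source may have more. Where it says the series, first, only, none or still open, it means among the compounds named here.

Of the compounds shown here, three built on one shared core have been tested in an assay on isolated protein for inhibition of protein kinase C theta type (Homo sapiens), read by TR-FRET, with a stated time of 2 h; on this read-out higher numbers stand for weaker inhibition and lower numbers for stronger inhibition. Compound 1 `N#Cc1cnc(NCc2cnccc2C(F)(F)F)cc1N[C@H]1C[C@H](O)C1` gives 900 nM. Compound 2 `N#Cc1cnc(NCc2ccccc2)cc1N[C@H]1CC[C@@H](O)CC1` gives 7000 nM, and compound 3 `COc1ncncc1CNc1cc(N[C@H]2CC[C@@H](O)CC2)c(C#N)cn1` gives 800 nM. Among these three numbers compound 1 stands second highest: its number and that of compound 3 lie within the usual scatter of each other, while compound 2 gives a number that is higher than compound 1 by more than the scatter. Within the data shown here, the only step between neighbours that differ in one place is an 8.8-fold lower number from compound 2 to compound 3 (0.94 log units; beyond the scatter).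

Compound 4 `CC1(C)[C@@H](Nc2cc(NCc3cnccc3C(F)(F)F)ncc2C#N)C[C@@H]1C(N)=O` differs from compound 1 in a single place: 3-carbamoyl-2,2-dimethylcyclobutyl in place of 3-hydroxycyclobutyl on a nitrogen on an aromatic ring. The group on the nitrogen on the aromatic ring is thus changed from 3-hydroxycyclobutyl to 3-carbamoyl-2,2-dimethylcyclobutyl.

Among the measured compounds shown here, no measured step touches this part of the core; the single measured step concerns the other end of the molecule and so offers no guide to size or direction here. The expectation therefore rests on compound 4 keeping every other feature of compound 1, which gives 900 nM. On that basis compound 4 is expected to give about 600 nM in this assay, most likely between 120 nM and 3000 nM. This estimate amounts to a 1.5-fold lower number from compound 1 to compound 4 (0.18 log units; within the scatter), a step expected to stay within the scatter.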

Compound 4, half-maximal inhibitory concentration: 1100 nM
For compound 4 the middle estimate is 1.8-fold (0.26 log units) below the measured one; low and high end bracket the measured number.
By their numbers in this assay, from the lowest: compounds 3, 1 and 4 (each within the scatter of the next); then compound 2.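

In this assay, among these compounds, the first measured change at this position, 3-carbamoyl-2,2-dimethylcyclobutyl in place of 3-hydroxycyclobutyl, gives a 1.2-fold higher number from compound 1 to compound 4 (0.09 log units; within the scatter), so the two compounds cannot be told apart on this read-out. With the rest of compound 1 held fixed, the group on this nitrogen can therefore grow from 5 to 9 heavy atoms, and its hydroxyl can give way to a carbamoyl group, with no difference beyond the scatter. Among the compounds shown here, no supporting measurement is available to explain this result, and the single step cannot separate the contribution of the carbamoyl group from that of the two added methyl groups, which could each matter alone or offset each other.

From the compounds shown here alone, it remains open how a 3-carbamoylcyclobutyl group without the two methyl groups, or a 3-hydroxy-2,2-dimethylcyclobutyl group, would compare with compound 1 and compound 4. Also open, going by these compounds, is whether a carboxylic acid or an aminomethyl group could take the place of the carbamoyl group, and whether the opposite arrangement of the two stereocentres would give a similar number.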